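This account rests on a few compounds, and the source may have more. Where it says the series, first, only, none or still open, it means among the compounds named here.

In an ADME assay on microsomes from liver (Mus musculus) for metabolic stability, read by LC-MS, using NADPH, tested at 4.6 uM (on this read-out lower numbers stand for a shorter-lived compound and higher numbers for a longer-lived compound), compound 1 `O=C(NCCCCc1ccccc1)n1cc(-c2ccccc2)oc1=O` gives 0.667 h. Compound 2 `COc1cc(-c2cn(C(=O)NCCCCc3ccccc3)c(=O)o2)ccc1F` gives > 1 h, which is a limit and not a number. Compound 3 `O=C(NCCCCc1ccccc1)n1cc(-c2ccncc2)oc1=O` gives > 1 h, also a limit, and so stands at the limit of > 1 h in this assay, at which 2 of the 3 values shown sit. Compound 4 `O=C(NCCCCc1ccccc1)n1cc(-c2cnccn2)oc1=O` differs from compound 3 in one place: pyrazin-2-yl in place of pyridin-4-yl on an aromatic carbon. This puts pyrazin-2-yl in place of pyridin-4-yl on an aromatic carbon. Two measured changes at this same carbon bear on it: an at least 1.4-fold higher number from compound 1 to compound 3 (0.17 log units; that floor lies within the scatter) and an at least 1.4-fold higher number from compound 1 to compound 2 (0.17 log units; that floor lies within the scatter). Both are floors within the scatter, while the third gives a step that the two limits leave unreadable from compound 2 to compound 3. No step beyond the scatter is therefore expected, and the estimated step is a step that the limit leaves unreadable from compound 3 to compound 4. Compound 4 is expected at 1.2 h, with an estimated range of 0.6 h to 2.4 h.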

Compound 4, half-life: 1 h
For compound 4 the middle estimate is 1.2-fold (0.08 log units) above the measured one; low and high end bracket the measured number.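

Pyrazin-2-yl in place of phenyl on this carbon gives a step with a readable size in this assay: a 1.5-fold higher number from compound 1 to compound 4 (0.18 log units; within the scatter). A six-membered aromatic ring with 2 hetero atoms is therefore tolerated here without a change beyond the scatter. In this assay pyrazin-2-yl also gives a number no higher from compound 3 to compound 4 (the limit leaves the size open) and a number no higher from compound 2 to compound 4 (the limit leaves the size open), and neither size can be read, because both of the starting values are limits: the limit of > 1 h in this assay, at which 2 of the 4 values shown sit.

As far as these compounds go, how far the half-lives of compound 2 and compound 3 extend stays open. So does whether a carboxylic acid or an amine on this carbon would shift the half-life beyond the scatter.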